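Removing one bromine from a dibromophenol: expected cell tolerance

The compounds below may be only part of what the source reports. "The series", "measured", "known", "first", "only" and "open" are said of these compounds alone.

Measured so far in an ADME assay on A549 cells (Homo sapiens) for cytotoxicity, read by MTT assay, with a stated time of 48 h; a higher number here means that more compound is tolerated, a lower number that less compound is tolerated:
- compound 1, `O=C1O/C(=C\c2cc(Br)c(O)c(Br)c2)C(c2ccc(O)c(Br)c2)=C1C(=O)c1cc(Br)c(O)c(Br)c1`: 40400 nM
- compound 2, `COc1ccc(C=C2OC(=O)C([C@@H](O)c3cc(Br)c(OC)c(Br)c3)=C2c2cc(Br)c(O)c(Br)c2)cc1`: 38500 nM
- compound 3, `COC(=O)C(C(=O)c1cc(Br)c(O)c(Br)c1)=C(C(=O)OC)c1cc(Br)c(O)c(Br)c1`: 19200 nM

All three compounds are brominated phenols built around related cores, and all three are tolerated by the cells at similar concentrations. Compound 3 has the lowest number of the three. Its distance to compound 2 lies within the usual scatter of this kind of measurement, so no order between compound 3 and compound 2 can be claimed. Its distance to compound 1 lies just beyond the scatter, so compound 1 is tolerated at a somewhat higher concentration than compound 3.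

Compound 4, `COC(=O)C(C(=O)c1cc(Br)c(O)c(Br)c1)=C(C(=O)OC)c1ccc(O)c(Br)c1`, has not yet been measured. It differs from compound 3 in one place: hydrogen in place of bromo on an aromatic carbon. Put another way, one of the two 3,5-dibromo-4-hydroxyphenyl groups of compound 3 becomes a 3-bromo-4-hydroxyphenyl group in compound 4.

Among the compounds with values here, no measured pair in this set shows what such a change does in this assay, so the expectation rests only on the narrow spread of the three values. The step of a 1.3-fold higher number from compound 3 to compound 4 (0.10 log units; within the scatter) is expected to be small, at most modestly upward, and may well stay within the scatter. Compound 4 is therefore estimated at 24000 nM, with a likely range from 11000 nM to 52000 nM.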

Compound 4, concentration lethal to 50% of the cells: > 100000 nM
Compound 4 ended at the assay's limit; the forecaster's own chance of this, stated with the estimate: 5%; at least 4.1-fold (0.61 log units) between middle value and limit.
By their numbers in this assay, from the lowest: compounds 3, 2 and 1 (each within the scatter of the next, the first and the last beyond it). At a limit, above all of these: compound 4.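

In this assay, replacing bromo with hydrogen on one aromatic carbon, ortho to a hydroxy group, gives an at least 5.2-fold higher number from compound 3 to compound 4 (0.71 log units; beyond the scatter). Within the data shown here, the three earlier compounds included no pair differing in one place, so they could not show that this single bromine matters: within this pair, turning one 3,5-dibromo-4-hydroxyphenyl group into a 3-bromo-4-hydroxyphenyl group changes how much compound the cells tolerate by more than the usual scatter. The value of compound 4, > 100000 nM, is a limit of the assay and not a number: the limit of > 100000 nM in this assay, at which 1 of the 4 values shown sits.

Going by these compounds, the true size of the step remains unknown, and this one pair cannot show whether removing a bromine from the other dibromophenol group, or from the same kind of group on a different core, would have a similar result. Also open, on these data alone, is what would happen if this position carried something other than bromo or hydrogen, such as a chlorine atom, a methyl group or an amine, and whether any of these would sit closer to compound 3 or to compound 4.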